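The source may hold more compounds than are shown below. What is called first, only, known or untested is meant among the compounds shown, and "the series" means these compounds.

Three compounds share one core, which carries a long saturated chain on a sulfur. Compound 1 `CCCCCCCCCCSc1nnc(Cc2nn(C)c(=O)c3ccccc23)n1C` ends that chain in a plain propyl; in an assay on isolated protein (Mus musculus) for inhibition of IL15-IL15 receptor (Homo sapiens), read by resazurin assay, with stated times of 30 min and 2.5 days (on this read-out lower numbers stand for stronger inhibition and higher numbers for weaker inhibition), compound 1 gives 7600 nM. Compound 2 `Cn1c(Cc2nn(C)c(=O)c3ccccc23)nnc1SCCCCCCCC(=O)Oc1ccc(Cl)cc1Cl` carries a (2,4-dichlorophenoxy)carbonyl at the same chain position, and in this assay compound 2 gives 800 nM. Compound 3 `Cn1c(Cc2nn(C)c(=O)c3ccccc23)nnc1SCCCCCCCC(=O)Nc1ccc(Cl)cc1` carries a (4-chlorophenyl)carbamoyl there, and in this assay compound 3 gives 800 nM. Both changes from the propyl moved the number the same way: a 9.5-fold lower number from compound 1 to compound 2 (0.98 log units; beyond the scatter) and a 9.5-fold lower number from compound 1 to compound 3 (0.98 log units; beyond the scatter). Between the two, however, no change at the digits printed from compound 2 to compound 3 (within the scatter), so compound 3 stands level with compound 2 at the digits shown, both well away from compound 1.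

Compound 4 `Cc1ccc(NC(=O)CCCCCCCSc2nnc(Cc3nn(C)c(=O)c4ccccc34)n2C)c(Cl)c1` keeps the amide and alters only the ring on it: 2-chloro-4-methylphenyl in place of 4-chlorophenyl on an amide-type nitrogen. Within the data shown here, no measured step changes this ring alone; the nearest comparison is the swap between compound 2 and compound 3, where exchanging one chlorinated ring and its link for another produced no movement. A change confined to the substituents of the aryl ring is therefore expected to stay within the scatter, with no change at the digits printed from compound 3 to compound 4 (within the scatter). Compound 4 is estimated to give 800 nM in this assay, within a range from 300 nM to 2500 nM.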

Compound 4, half-maximal inhibitory concentration: 2300 nM
The estimate for compound 4 lay 2.9-fold (0.46 log units) below the measured number; measured number inside the range.
By their numbers in this assay, from the lowest: compounds 2 and 3 (each within the scatter of the next); then compound 4; then compound 1.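

The aryl ring on the amide nitrogen turns out to be sensitive in this assay: there is a 2.9-fold higher number from compound 3 to compound 4 (0.46 log units; beyond the scatter), so replacing 4-chlorophenyl with 2-chloro-4-methylphenyl, a ring with only one more heavy atom, moves the number beyond the scatter, although the earlier exchange of ring and link between compound 2 and compound 3 moved nothing. The ester comparison gives the same picture, with a 2.9-fold higher number from compound 2 to compound 4 (0.46 log units; beyond the scatter), while part of the gain over the plain propyl end remains, with a 3.3-fold lower number from compound 1 to compound 4 (0.52 log units; beyond the scatter), so the substituted aryl amide in compound 4 still improves on the simple chain of compound 1, though by less than the 4-chlorophenyl amide does. No measurement available here explains why this ring change shifts the number.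

The new ring differs from the old in both its chlorine placement and its added methyl, and a plain 2-chlorophenyl or 4-methylphenyl on the same amide would show which of the two goes with the shift. Going by these compounds, it also remains open how the number would respond to an unsubstituted phenyl on the amide or to a carboxylic acid at the end of the chain.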